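A few compounds are considered here, and "the series" means these few. Any claim that something is new, unique, unknown or untested is made for them only; others in the source may bear on it.

Three compounds have been measured so far in an ADME assay on HepG2 2.2.15 cells (Homo sapiens) for cytotoxicity; a lower number here means that less compound is tolerated, a higher number that more compound is tolerated

- compound 1 `CC(=O)OCCc1c(-c2ccccc2Cl)c2cc(Cl)ccc2[nH]c1=O` gives 27000 nM
- compound 2 `COCC(=O)OCCc1c(-c2ccccc2Cl)c2cc(Cl)ccc2[nH]c1=O` gives 74000 nM
- compound 3 `CC(=O)OCC(=O)OCCc1c(-c2ccccc2Cl)c2cc(Cl)ccc2[nH]c1=O` gives 100000 nM

Compound 3, at 100000 nM in this assay, shares the upper end of the set with its nearest neighbour (a 1.4-fold higher number from compound 2 to compound 3 (0.13 log units; within the scatter)). The remaining gap is larger (a 3.7-fold higher number from compound 1 to compound 3 (0.57 log units; beyond the scatter)) and lies beyond the scatter. Compound 4 `O=C(OCCc1c(-c2ccccc2Cl)c2cc(Cl)ccc2[nH]c1=O)c1ccccc1` has not yet been measured. Going by the values given here, it carries phenyl in place of acetoxymethyl on a carbonyl carbon and no measured compound has a ring at this place. Two steps therefore bear on it only indirectly. Both change the group on that same carbonyl carbon (a 2.7-fold higher number from compound 1 to compound 2 (0.44 log units; beyond the scatter) and a 3.7-fold higher number from compound 1 to compound 3 (0.57 log units; beyond the scatter)) and both are modest. Phenyl removes the acetoxymethyl that one of those steps added, so a modest move back towards compound 1 is expected (a 2.5-fold lower number from compound 3 to compound 4 (0.40 log units; beyond the scatter)) with little certainty. Compound 4 is estimated at 40000 nM with a range from 15000 nM to 100000 nM as the likely span.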

Compound 4, half-maximal cytotoxic concentration: 43000 nM
Beside the measured number, compound 4's estimate is 1.1-fold (0.03 log units) below it; measured number inside the range.
By their numbers in this assay, from the lowest: compounds 1, 4, 2 and 3 (each within the scatter of the next, the first and the last beyond it).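

In this assay, going by these compounds alone, a ring on this carbonyl carbon is seen here for the first time, and phenyl cannot be told apart from methyl (a 1.6-fold higher number from compound 1 to compound 4 (0.20 log units; within the scatter)) or from methoxymethyl (a 1.7-fold lower number from compound 2 to compound 4 (0.24 log units; within the scatter)), as both steps lie within the scatter. Only the change from acetoxymethyl to phenyl reads as a real one (a 2.3-fold lower number from compound 3 to compound 4 (0.37 log units; beyond the scatter)), and it is modest, so an aromatic ring at this place brings no marked shift in the number. Nothing available here accounts for these differences.

Going by these compounds, it remains open how a saturated ring such as cyclohexyl, a phenyl ring carrying an amine, or a longer alkyl chain would read on this carbonyl carbon. On these data alone, all four compounds carry an ester at this place, so it is also open how an amide or an ether in its stead would read.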